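The compounds below may be only part of what the source reports. "The series", "measured", "known", "first", "only" and "open" are said of these compounds alone.

Measured compounds in a functional assay on IMR-32 cells for inhibition of Voltage-dependent N-type calcium channel subunit alpha-1B (Homo sapiens), read by calcium flux; on this read-out lower numbers stand for stronger inhibition and higher numbers for weaker inhibition:

compound 1 `COC(=O)c1cccc(C2C(C(=O)O)=C(C)N=C(C)/C2=C(/O)OC/C=C/c2ccccc2)c1`, 4600 nM
compound 2 `CC1=NC(C)=C(C(=O)O)C(c2cccc(F)c2)/C1=C(\O)OC/C=C/c1ccccc1`, 1300 nM
compound 3 `CC1=NC(C)=C(C(=O)O)C(c2cccc(Br)c2)/C1=C(\O)OC/C=C/c1ccccc1`, 790 nM

Compound 3 gives the lowest number of the three. One step is a 1.6-fold lower number from compound 2 to compound 3 (0.22 log units; within the scatter), so those two cannot be ordered; a second step is a 5.8-fold lower number from compound 1 to compound 3 (0.77 log units; beyond the scatter), and the third is a 3.5-fold lower number from compound 1 to compound 2 (0.55 log units; beyond the scatter). Both steps beyond the scatter come from replacing methoxycarbonyl on the aromatic ring of compound 1 with a halogen, and they are of modest size.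

Compound 4 `CC1=NC(C)=C(C(=O)O)C(c2ccoc2)/C1=C(\O)OC/C=C/c1ccccc1` differs from compound 3 in one place: furan-3-yl in place of 3-bromophenyl on a saturated ring carbon. Within the data shown here, none of the measured steps changes the ring itself; all three keep a six-membered carbon ring and vary only its substituent. The measured steps therefore bear on the step to compound 4 only in showing that this position moves the read-out by modest amounts. With no halogen and a smaller ring, a shift back towards the number of compound 1 is the expectation, without a measured anchor. The expected step is a 3.2-fold higher number from compound 3 to compound 4 (0.50 log units; beyond the scatter), a modest rise in the number. For compound 4 in this assay the estimate is 2500 nM, with a range from 900 nM to 7000 nM.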

Compound 4, half-maximal inhibitory concentration: 11000 nM
Beside the measured number, compound 4's estimate is 4.4-fold (0.64 log units) below it; measured number above the stated range.
By their numbers in this assay, from the lowest: compounds 3 and 2 (each within the scatter of the next); then compound 1; then compound 4.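

In this assay, among these compounds, furan-3-yl on the saturated ring carbon gives a 14-fold higher number from compound 3 to compound 4 (1.14 log units; beyond the scatter), the first large step at this position, and the comparison with the 3-fluorophenyl compound gives an 8.5-fold higher number from compound 2 to compound 4 (0.93 log units; beyond the scatter). Even the 3-(methoxycarbonyl)phenyl compound, the highest number among the earlier compounds, lies below the furan, with a 2.4-fold higher number from compound 1 to compound 4 (0.38 log units; beyond the scatter), so all three six-membered aromatic rings carrying a substituent give lower numbers than this five-membered ring with its oxygen, and changing the ring itself moves the read-out further than the earlier substituent swaps on the phenyl ring did. No measurement on hand accounts for the size of this rise.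

The furan-3-yl group differs from the phenyl groups at once in ring size, in its ring oxygen and in lacking a substituent, and the compounds shown do not separate these three changes. Open cases are whether unsubstituted phenyl sits nearer the halogenated compounds or nearer the furan, and whether thiophen-3-yl or a bromofuran recovers any of the lost inhibition.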